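The source may report more compounds than this note shows. Statements on the series, on what has been measured and on what is new or still open speak of the compounds shown alone.

In a physicochemical assay for solubility, in phosphate buffer, measured as thermodynamic solubility, at pH 7.4 (a higher number here means a more soluble compound, a lower number a less soluble compound), compound 1 `CS(=O)(=O)NC(=O)CCc1cn(-c2ccc(Br)cc2)nc1-c1ccc(Cl)cc1` gives 170000 nM. Compound 3 `CS(=O)(=O)NC(=O)CCc1cn(-c2ccc(Br)cc2)nc1-c1ccccc1` gives 200000 nM, within the scatter of compound 1, while compound 2 `CS(=O)(=O)NC(=O)CCc1cn(-c2ccc(C#N)cc2)nc1-c1ccc(Cl)cc1` gives the lowest number of the three, 75000 nM.

Compound 4 `CS(=O)(=O)NC(=O)CCCc1cn(-c2ccc(Br)cc2)nc1-c1ccc(Cl)cc1` keeps the core of compound 1 and differs in a single place, on a saturated chain carbon, two bonds along the chain from an aromatic carbon: ((methylsulfonyl)carbamoyl)methyl in place of (methylsulfonyl)carbamoyl on a saturated chain carbon, two bonds along the chain from an aromatic carbon.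

Neither measured step touches this chain. Cyano in place of bromo on an aromatic carbon gives a 2.3-fold lower number from compound 1 to compound 2 (0.36 log units; beyond the scatter), a modest change. Hydrogen in place of chloro on an aromatic carbon gives a 1.2-fold higher number from compound 1 to compound 3 (0.07 log units; within the scatter). These steps show only how far single changes elsewhere in the structure moved the number, so no measurement here speaks directly to a longer chain. A small step is therefore expected, leaning slightly downward and probably not beyond the scatter.

The expected change is a 1.3-fold lower number from compound 1 to compound 4 (0.12 log units; within the scatter). For compound 4 the estimated value is 130000 nM, with an expected range from 60000 nM to 260000 nM.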

Compound 4, solubility: 135000 nM
Beside the measured number, compound 4's estimate is 1.0-fold (0.02 log units) below it; the range from low to high includes it.
By their numbers in this assay, from the lowest: compounds 2, 4, 1 and 3 (each within the scatter of the next, the first and the last beyond it).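

In this assay, among the compounds shown here, the step to ((methylsulfonyl)carbamoyl)methyl in place of (methylsulfonyl)carbamoyl gives a 1.3-fold lower number from compound 1 to compound 4 (0.10 log units; within the scatter) and so provides the first measurement of a change on this saturated chain carbon. The step lies within the scatter, so with the rest of the core of compound 1 kept, this change to the chain leaves no measurable difference in the number. No measurement here offers a reason for the size of this step. Going by these compounds, whether a longer chain, such as 2-((methylsulfonyl)carbamoyl)ethyl, would also stay within the scatter of compound 1 remains open, as a single step gives no trend along the chain. Also open, on these data alone, is what a carboxylic acid in place of the (methylsulfonyl)carbamoyl would do to the number.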